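Ring swaps at the enone carbon of the shared core

The compounds below may be only part of what the source reports. "The series", "measured", "known", "first", "only" and "open" are said of these compounds alone.

Values in an assay on CHO cells for displacement of a labelled ligand from Substance-P receptor (Homo sapiens), in the presence of a further agent that is not named here; on this read-out higher numbers stand for weaker inhibition and lower numbers for stronger inhibition:
- compound 1 `C[C@@H](O[C@H]1CN2C(=O)C=C(c3cc[n+]([O-])cc3)CC2[C@@H]1c1ccc(F)cc1)c1cc(C(F)(F)F)cc(C(F)(F)F)c1`: 2.1 nM
- compound 2 `C[C@@H](O[C@H]1CN2C(=O)C=C(c3cc[nH]c(=O)c3)CC2[C@@H]1c1ccc(F)cc1)c1cc(C(F)(F)F)cc(C(F)(F)F)c1`: 3.9 nM
- compound 3 `C[C@@H](O[C@H]1CN2C(=O)C=C(c3cnn(C)c3)CC2[C@@H]1c1ccc(F)cc1)c1cc(C(F)(F)F)cc(C(F)(F)F)c1`: 5.4 nM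

Compound 3 carries the highest of the three numbers in this assay. Its nearest neighbour is compound 2, with a 1.4-fold higher number from compound 2 to compound 3 (0.14 log units; within the scatter); the furthest is compound 1, with a 2.6-fold higher number from compound 1 to compound 3 (0.41 log units; beyond the scatter), a modest step. Between compound 1 and compound 2 the step is a 1.9-fold higher number from compound 1 to compound 2 (0.27 log units; within the scatter).

Compound 4 `C[C@@H](O[C@H]1CN2C(=O)C=C(C3=CCOCC3)CC2[C@@H]1c1ccc(F)cc1)c1cc(C(F)(F)F)cc(C(F)(F)F)c1` differs from compound 3 in one place: a group of 6 heavy atoms (5 carbon, 1 oxygen; one six-membered non-aromatic ring with 1 hetero atom) in place of a group of 6 heavy atoms (4 carbon, 2 nitrogen; one five-membered aromatic ring with 2 hetero atoms), on a double-bonded ring carbon. The three measured steps all exchange one ring for another at the same double-bonded ring carbon, and each stays small, the largest being a 2.6-fold higher number from compound 1 to compound 3 (0.41 log units; beyond the scatter). Among the compounds with values here, none of them, however, replaces an aromatic ring by a non-aromatic one, so no measured step bears directly on the present change; they show only that this position has so far tolerated ring exchange with little movement in this assay.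

On that basis compound 4 is expected to sit close to compound 3, with the step of a 1.5-fold higher number from compound 3 to compound 4 (0.17 log units; within the scatter) estimated as not beyond the scatter in either direction. The estimate for compound 4 in this assay is 8 nM, with a range of 3 nM to 25 nM, drawn wider than usual because the measured steps of a 2.6-fold higher number from compound 1 to compound 3 (0.41 log units; beyond the scatter) and a 1.4-fold higher number from compound 2 to compound 3 (0.14 log units; within the scatter) concern aromatic rings only.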

Compound 4, half-maximal inhibitory concentration: 9.6 nM
The estimate for compound 4 lay 1.2-fold (0.08 log units) below the measured number; the range from low to high includes it.
By their numbers in this assay, from the lowest: compounds 1, 2, 3 and 4 (each within the scatter of the next, the first and the last beyond it).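

In this assay, the only non-aromatic ring among these compounds stays level with the 1-methyl-1H-pyrazol-4-yl ring, with a 1.8-fold higher number from compound 3 to compound 4 (0.25 log units; within the scatter), so an aromatic ring on this double-bonded ring carbon is not required to keep the number close to that of compound 3. Set against the two six-membered aromatic rings, the same ring does register, with a 2.5-fold higher number from compound 2 to compound 4 (0.39 log units; beyond the scatter) and a 4.6-fold higher number from compound 1 to compound 4 (0.66 log units; beyond the scatter); both steps are modest, but the second is the widest in the set, so this position is less indifferent to ring exchange than the earlier steps alone suggested. No measurement is available that accounts for these steps.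

Still open, on these data alone, is whether the double bond in the new ring matters, since a fully saturated tetrahydropyran ring at this carbon would separate that feature from the loss of aromaticity. Also open is how this assay would respond to a group of another kind on this carbon, such as a piperidine amine, a carboxylic acid or a longer open chain, as all four compounds shown carry a ring here.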